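A few compounds are considered here, and "the series" means these few. Any claim that something is new, unique, unknown or untested is made for them only; others in the source may bear on it.

In a functional assay for inhibition, with Homo sapiens as the target (on this read-out lower numbers stand for stronger inhibition and higher numbers for weaker inhibition), compound 1 `Sc1nncc2cncn12` gives > 48000 nM, a value that is a limit of the measurement rather than a number. In this assay compound 2 `CCCc1ncn2c(O)nncc12` likewise gives > 48000 nM, again only a limit. Both values shown sit at the limit of > 48000 nM in this assay, at which 2 of the 2 values shown sit, so compound 2 stands at the edge of what the measurement can report. Compound 3 `Oc1nncc2cncn12` differs from compound 2 by hydrogen in place of propyl on an aromatic carbon. Among the measured compounds shown here, no measured step of this kind is available, so no change beyond the usual scatter is expected. The estimated step is a step that the limit leaves unreadable from compound 2 to compound 3. Compound 3 is therefore expected to give 100000 nM, within 30000 nM to 500000 nM, most likely reported again only as a limit.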

Compound 3, half-maximal inhibitory concentration: > 48000 nM
Compound 3: a limit, no number; the forecaster's own chance of this, stated with the estimate: 85%; the middle value is on the limit's open side.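

Compound 3 again gives only a limit, so its steps from compound 1 and compound 2 cannot be read: the limit of > 48000 nM in this assay, at which 3 of the 3 values shown sit. The compounds shown leave open what change to the shared core, if any, would give a readable number in this assay.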